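Sulfone and thioether enones against DU-145 growth

The source may report more compounds than this note shows. Statements on the series, on what has been measured and on what is new or still open speak of the compounds shown alone.

Measured so far:
compound 1 `CN(C)c1ccc(/C=C(\C(=O)c2ccc(Br)cc2)S(=O)(=O)Cc2ccc(F)cc2)cc1` — 50000 nM
compound 2 `O=C(/C(=C\c1c[nH]c2ccc(Br)cc12)SCc1ccc(F)cc1)c1ccc(Cl)cc1` — 50000 nM
compound 3 `O=C(O)c1ccc(C(=O)/C(=C\c2ccccc2F)SCc2ccc(Br)cc2)cc1` — 10000 nM

The three measured compounds were run in a functional assay on DU-145 cells (Homo sapiens) for inhibition, read by trypan blue exclusion, with a stated time of 96 h; on this read-out lower numbers stand for stronger inhibition of growth and higher numbers for weaker inhibition of growth. Compound 1 gives 50000 nM and compound 2 gives 50000 nM; these two stand level at the digits shown, within the scatter of each other, and together they hold the highest numbers of the set. Compound 3 gives 10000 nM, a lower number than compound 1 and beyond the scatter. Going by the values given here, no two of the measured compounds differ in only one place, so no single-change step is available among them.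

Compound 4 `COc1ccc(/C=C(\C(=O)c2ccc(Br)cc2)S(=O)(=O)Cc2ccc(F)cc2)cc1` is the next analogue to be measured. It differs from compound 1 as follows: methoxy in place of dimethylamino on an aromatic carbon. Among the compounds with values here, no measured pair in this set isolates a change of this kind, so the size of the step cannot be read from the data, only expected.

The expectation for compound 4 is a number close to that of compound 1, with a step of no change at the digits printed from compound 1 to compound 4 (within the scatter) that stays within the scatter. Compound 4 is therefore estimated at 50000 nM in this assay, with a range from 15000 nM to 100000 nM.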

Compound 4, concentration for 50% growth inhibition: 25000 nM
Compound 4: middle estimate off by 2.0-fold (0.30 log units), on the high side; measured number inside the range.
By their numbers in this assay, from the lowest: compound 3; then compounds 4, 1 and 2 (each within the scatter of the next).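

Methoxy in place of dimethylamino on an aromatic carbon, para to a large group, gives in this assay a 2.0-fold lower number from compound 1 to compound 4 (0.30 log units; within the scatter) and is the first single-change step in the series. The earlier compounds shown here differ from one another in more than one place, so they could not show how much this position alone contributes; on the core of compound 1, this exchange of 4-(dimethylamino)phenyl for 4-methoxyphenyl leaves the result inside the usual scatter, and the two groups cannot be ranked. No measurement here bears on why the step is this size.

One step at one position does not show whether this position is insensitive in general, and a hydroxyl, a primary amine or a carboxylic acid on the same aromatic carbon could still give a step beyond the scatter. Nor do the compounds shown say whether the same exchange would give a similar step on the core of compound 2 or the core of compound 3, where the sulfur linker and other positions also differ.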